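Oral dog exposure across aryl-cycloalkyl side-chain variants

The source may hold more compounds than are shown below. What is called first, only, known or untested is meant among the compounds shown, and "the series" means these compounds.

In an in vivo ADME assay on the whole organism (plasma) for pharmacokinetics, with Canis familiaris (Canis lupus familiaris) as the target, at a dose of 1 mg/kg by the oral route (on this read-out lower numbers stand for lower exposure and higher numbers for higher exposure at the dose given), compound 2 `Cc1cnc(NCC2(c3ccccn3)CC2)c(=O)n1CC(=O)NCc1ccc2c(N)noc2c1` gives 1680 nM and stands at the upper of the two numbers shown, while compound 1 `Cc1cnc(NCC2(c3ccccc3)CCC2)c(=O)n1CC(=O)NCc1ccc2c(N)noc2c1` gives 1310 nM in this assay, a value within the scatter of compound 2. Among the measured compounds shown here, the only measured step, a 1.3-fold higher number from compound 1 to compound 2 (0.11 log units; within the scatter), exchanges one aryl-cycloalkyl group for another and moves the read-out by no more than the scatter. Compound 3 `Cc1cnc(NCC2(c3ccc(F)cc3)CC2)c(=O)n1CC(=O)NCc1ccc2c(N)noc2c1` continues this variation on the same saturated chain: 4-fluorophenyl in place of pyridin-2-yl on a saturated ring carbon. For the measured compounds named here, no measured step exchanges a pyridinyl ring for a fluorophenyl ring in this assay, so the expectation rests on the single step available, which left the number essentially unchanged. The step from compound 2 to compound 3 is therefore expected to stay within the scatter, a 1.1-fold lower number from compound 2 to compound 3 (0.05 log units; within the scatter), with no direction favoured. For compound 3 the estimated maximal plasma concentration in this assay is 1500 nM, with a range from 750 nM to 3000 nM.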

Compound 3, maximal plasma concentration in the Canis familiaris assay: 1780 nM
Beside the measured number, compound 3's estimate is 1.2-fold (0.07 log units) below it; the range from low to high includes it.
By their numbers in the Canis familiaris assay, from the lowest: compounds 1, 2 and 3 (each within the scatter of the next).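

In the Canis familiaris assay compound 2 gives 1680 nM and compound 3 gives 1780 nM. In the Canis familiaris assay, the exchange on the saturated ring carbon reads a 1.1-fold higher number from compound 2 to compound 3 (0.03 log units; within the scatter), so pyridin-2-yl and 4-fluorophenyl are not told apart by maximal plasma concentration at this position. The wider exchange of the whole side-chain group reads a 1.4-fold higher number from compound 1 to compound 3 (0.13 log units; within the scatter), which places all three aryl-cycloalkyl variants, including the 1-phenylcyclobutyl group of compound 1, within the scatter of one another. In a physicochemical assay for acid dissociation, compound 2 gives 8.6 and compound 3 gives 8.6. In the physicochemical assay the exchange on the ring carbon reads no change at the digits printed from compound 2 to compound 3 (within the scatter), and nothing available accounts for the exposure figures.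

On these data alone, compound 1 differs from compound 2 and compound 3 in both the aryl group and the cycloalkyl ring, so the separate contribution of each to the exposure stays open. Also open, as far as these compounds go, is whether this insensitivity holds beyond aryl-cycloalkyl groups, for instance with an amine or a carboxylic acid on the aromatic ring, or with a longer chain in place of the cyclopropyl ring.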